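Exchanging a tert-butoxymethyl group for a dihydroindolyl group

The source may report more compounds than this note shows. Statements on the series, on what has been measured and on what is new or still open speak of the compounds shown alone.

Measured so far:
compound 1, `COc1ccc2[nH]c(C(=O)N3CC(=O)N(Cc4ccccc4)[C@@H](CCc4ccccc4)C3)cc2c1`, 4400 nM
compound 2, `COc1ccc2[nH]c(C(=O)N3CC(=O)N(Cc4ccccc4)[C@@H](COC(C)(C)C)C3)cc2c1`, 65500 nM

In a physicochemical assay for solubility, read by spectrophotometry, in phosphate buffer, with a stated time of 2 h, at pH 7.4 (on this read-out lower numbers stand for lower solubility and higher numbers for higher solubility), compound 2 gives the higher of the two numbers, and its nearest neighbour is compound 1, which lies well below it. For the measured compounds named here, the only measured step, a 15-fold higher number from compound 1 to compound 2 (1.17 log units; beyond the scatter), came from swapping the benzyl group on the side chain for a tert-butoxy group.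

Compound 3, `COc1ccc2[nH]c(C(=O)N3CC(=O)N(Cc4ccccc4)[C@@H](N4CCc5ccccc54)C3)cc2c1`, is not yet measured. It differs from compound 2 in one place: 2,3-dihydro-1H-indol-1-yl in place of (tert-butoxy)methyl on a saturated ring carbon. This change touches the same saturated ring carbon as the step from compound 1 to compound 2, but it replaces the whole side chain with a group that brings back an aromatic ring, much as compound 1 carries one. Because a 15-fold higher number from compound 1 to compound 2 (1.17 log units; beyond the scatter) was large, a step of similar size in the opposite direction is expected, and the expected step is an 11-fold lower number from compound 2 to compound 3 (1.04 log units; beyond the scatter). Compound 3 is therefore estimated at 6000 nM, with a likely range from 1500 nM to 25000 nM.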

Compound 3, solubility: 7000 nM
Beside the measured number, compound 3's estimate is 1.2-fold (0.07 log units) below it; the measured number falls inside the stated range.
By their numbers in this assay, from the lowest: compounds 1 and 3 (each within the scatter of the next); then compound 2.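

In this assay, putting 2,3-dihydro-1H-indol-1-yl in place of (tert-butoxy)methyl on this saturated ring carbon gives a 9.4-fold lower number from compound 2 to compound 3 (0.97 log units; beyond the scatter) on the read-out, so this position can move the number down as well as up. Phenethyl and 2,3-dihydro-1H-indol-1-yl, the two groups here that carry an aromatic ring, cannot be told apart, since exchanging them gives a 1.6-fold higher number from compound 1 to compound 3 (0.20 log units; within the scatter) as the result, and among these three compounds only compound 2, with no ring in this group, stands apart. Nothing available explains why the numbers differ in this way.

Three groups are too few to show whether the aromatic ring itself is what matters. As far as these compounds go, a plain hexyl chain, a cyclohexyl ring or a side chain ending in an amine or a carboxylic acid could test this, and where each would fall remains open.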